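Series notes: estimating compound 3 from compound 2

The source may hold more compounds than are shown below. What is called first, only, known or untested is meant among the compounds shown, and "the series" means these compounds.

Of the compounds shown here, two carry numbers so far. Compound 1 `COc1ccc(-c2cc(/C=C/C(=O)c3ccc(N)cc3)[nH]n2)cc1` gives 56% in a functional assay on CAKI-1 cells (Homo sapiens) for cytotoxicity, read by sulforhodamine B assay, with a stated time of 48 h, tested at 1 uM; a higher number here means a weaker effect of the compound at the concentration tested, a lower number a stronger effect. Compound 2 `COc1cc(-c2cc(/C=C/C(=O)c3ccc(Cl)c(Cl)c3)[nH]n2)cc(OC)c1OC` gives 87% in this assay, the highest of the two numbers; its nearest neighbour, compound 1, sits a good way lower, and that gap lies beyond the scatter. Among the compounds with values here, no pair of measured compounds differs in only one place, so nothing in the measured set isolates a single structural change.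

Compound 3 `COc1ccc(C(=O)/C=C/c2cc(-c3cc(OC)c(OC)c(OC)c3)n[nH]2)cc1OC` has not yet been measured in this assay. Relative to compound 2 it differs as follows: 3,4-dimethoxyphenyl in place of 3,4-dichlorophenyl on a carbonyl carbon. Within the data shown here, no measured pair shows this kind of change, so the step is expected to be none beyond the scatter: a number 3 percentage points lower from compound 2 to compound 3 (within the scatter). Among the measured compounds shown here, compound 3 is accordingly expected to give about 84% in this assay, inside a range from 62% to 100% that is kept wide because no reference step exists.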

Compound 3, a percentage reported as activity, at one concentration (the size of the read-out at that concentration, not a potency): 94%
Compound 3: middle estimate off by 10 percentage points, on the low side; the range from low to high includes it.
By their numbers in this assay, from the lowest: compound 1; then compounds 2 and 3 (each within the scatter of the next).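

Within the data shown here, on the carbonyl carbon, 3,4-dimethoxyphenyl in place of 3,4-dichlorophenyl gives a number 7 percentage points higher from compound 2 to compound 3 (within the scatter) in this assay, the only single-place step so far. This exchange of two chlorine atoms for two methoxy groups on the phenyl therefore leaves the read-out within the scatter, and at the tested concentration this assay does not separate the two groups. Nothing on hand bears on why these two groups read alike.

As far as these compounds go, it remains open whether a nitrile or a carboxylic acid at this place, or a bare phenyl, would shift the read-out beyond the scatter. Compound 1 differs from compound 2 and compound 3 in more than one place, so no single structural change can be read from it.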